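Demethylation of the methoxy group in a pyrazole-linked series

The compounds below may be only part of what the source reports. "The series", "measured", "known", "first", "only" and "open" are said of these compounds alone.

In a functional assay on EKVX cells (Homo sapiens) for cytotoxicity, read by sulforhodamine B assay, with a stated time of 48 h, tested at 0.001 uM (on this read-out lower numbers stand for a stronger effect and higher numbers for a weaker effect at the one concentration tested), compound 1 `COc1cc(C)cc(-c2nn(CC#N)cc2-c2ccc(-c3cccc(C(C)=O)c3)nc2)c1` gives 99%. Compound 2 `Cc1cc(O)cc(-c2nn(CC#N)cc2-c2ccnc(-c3ccc(Oc4ccccc4)cc3)c2)c1` gives 103% in this assay. Compound 3 `COc1cc(C)cc(-c2nn(CC#N)cc2-c2ccnc(-c3ccc(N(C)C)cc3)c2)c1` gives 91%, the lowest of the three numbers; its gap to compound 1 lies within the scatter, its gap to compound 2 beyond it. All three numbers sit close to full activity, so the single concentration used here shows little effect for any of them.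

Compound 4 `Cc1cc(O)cc(-c2nn(CC#N)cc2-c2ccnc(-c3ccc(N(C)C)cc3)c2)c1` is the next member. It differs from compound 3 in one place: hydrogen in place of methyl on an oxygen on an aromatic ring. Among the compounds with values here, compound 2 also carries the hydroxy group, but its other aryl group is different, so no clean pair shows what the methyl-to-hydrogen swap alone does.

With no measured step of this kind in the series, no shift beyond the scatter is expected from compound 3 to compound 4; the expected step is a number 5 percentage points higher from compound 3 to compound 4 (within the scatter). Compound 4 is therefore estimated at 96% in this assay, with a range from 84% to 108%.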

Compound 4, a percentage reported as activity, at one concentration (the size of the read-out at that concentration, not a potency): 96%
The estimate for compound 4 equals the measured number at the digits printed, within the range that was stated.
By their numbers in this assay, from the lowest: compounds 3, 4, 1 and 2 (each within the scatter of the next, the first and the last beyond it).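

Within the data shown here, replacing methoxy with hydroxy, on an oxygen on an aromatic ring, gives in this assay a number 5 percentage points higher from compound 3 to compound 4 (within the scatter), the first reading of this change with the rest of the molecule held constant. With the hydroxy group held constant, dimethylamino in place of phenoxy on an aromatic carbon gives a number 7 percentage points lower from compound 2 to compound 4 (within the scatter), so neither single change separates its pair at this one concentration. No supporting data bear on these results.

As far as these compounds go, whether either pair separates at higher concentrations remains open, since a single low concentration gives no potency. Also open, from the compounds shown here alone, is whether an ethoxy group or an amino group at the place of the hydroxy group, or a carboxylic acid in place of dimethylamino, would move the read-out beyond the scatter.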